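Cytotoxicity notes: chloro for ester-bearing alkoxy side chain

This account rests on a few compounds, and the source may have more. Where it says the series, first, only, none or still open, it means among the compounds named here.

The series shares a core carrying an aryl group and an amine substituent; compound 1 `CCCCOc1ccc(-c2nc3ncccn3c2NC(C)(C)CC(C)(C)C)cc1` is the reference, and in a toxicity assay on A549 cells (Homo sapiens) for cytotoxicity, read by luminescence and CellTiter-Glo, with a stated time of 48 h (on this read-out lower numbers stand for higher toxicity in this test and higher numbers for lower toxicity in this test), compound 1 gives 29000 nM. Compound 2 `CCCCOc1ccc(-c2nc3ncccn3c2Nc2ccccc2)cc1` differs only at the amine, and in this assay compound 2 gives 100000 nM. Among the compounds with values here, the only measured single change is a 3.4-fold higher number from compound 1 to compound 2 (0.54 log units; beyond the scatter), at the amine nitrogen, not at the aryl position considered here. Compound 3 `CCOC(=O)CCCOc1ccc(-c2nc3ncccn3c2NC2CCCCC2)cc1` carries a cyclohexyl amine and an ester-bearing chain on the aryl ring. For compound 3 the read-out in this assay is a limit, > 100000 nM, not a number; it sits at the limit of > 100000 nM in this assay, at which 1 of the 3 values shown sits. Compound 4 `Clc1ccc(-c2nc3ncccn3c2NC2CCCCC2)cc1` is obtained by the change (chloro in place of 3-(ethoxycarbonyl)propoxy on an aromatic carbon). Within the data shown here, no measured step touches this aryl position, so the step from compound 1 to compound 2 gives no direct guidance, and only the closeness of compound 3 to the limit frames the expectation. Compound 4 is therefore expected at roughly 60000 nM, within 20000 nM to 100000 nM. The step implied from compound 3 is estimated as an at least 1.6-fold lower number from compound 3 to compound 4 (0.22 log units; that floor lies within the scatter), with a substantial chance that only a limit is again reported.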

Compound 4, half-maximal cytotoxic concentration: > 100000 nM
Compound 4 gave a limit, no number; the forecaster's own chance of this, stated with the estimate: 40%; middle value at least 1.6-fold (0.22 log units) away from the limit.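

Compound 3 and compound 4 both give a limit, not a number, in this assay, so the step between them cannot be read: the limit of > 100000 nM in this assay, at which 2 of the 4 values shown sit.

The compounds shown leave open how chloro and 3-(ethoxycarbonyl)propoxy on the aromatic carbon compare in this read-out, and whether exchanging one for the other changes the cytotoxicity at all.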